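This account rests on a few compounds, and the source may have more. Where it says the series, first, only, none or still open, it means among the compounds named here.

Compounds measured in an assay on HEK293 cells for positive allosteric modulation of metabotropic glutamate receptor 5 (Homo sapiens), read by FLIPR, with a stated time of 1 h; on this read-out higher numbers stand for an effect only at larger amounts of compound and lower numbers for an effect already at smaller amounts:
compound 1 `O=C1NCCc2nc(C#Cc3ccccc3F)sc21` gives 1500 nM
compound 2 `C(#Cc1nc2c(s1)CN(C1CCCCC1)CC2)c1ccccc1` gives > 10000 nM

For compound 2 the value is a limit of the measurement, not a number (the limit of > 10000 nM in this assay, at which 1 of the 2 values shown sits). Compound 2 therefore stands at the upper edge of what this assay shows, while compound 1 gives a definite value.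

Compound 3 `O=C(C1CC12CCC2)N1CCc2nc(C#Cc3ccccc3)sc2C1` differs from compound 2 by a group of 8 heavy atoms (7 carbon, 1 oxygen; one three-membered non-aromatic ring of carbon only, one four-membered non-aromatic ring of carbon only) in place of a group of 6 heavy atoms (6 carbon; one six-membered non-aromatic ring of carbon only), on an amine nitrogen in a ring. Going by the values given here, no measured step covers this change. The entering group carries a carbonyl on the ring nitrogen, and compound 1, whose core also carries a carbonyl, gives 1500 nM. A move toward lower numbers, beyond the scatter, is expected; the expected step is an at least 5.0-fold lower number from compound 2 to compound 3 (0.69 log units; beyond the scatter). Compound 3 is estimated at 2000 nM, between 500 nM and 10000 nM.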

Compound 3, half-maximal effective concentration: 3.9 nM
Compound 3: middle estimate off by 510-fold (2.71 log units), on the high side; measured number below the stated range.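

The amine nitrogen in the ring is a position where the group carried can change the read-out greatly: in this assay, replacing cyclohexyl with the entering group, which has a carbonyl and two small carbon rings, gives an at least 2500-fold lower number from compound 2 to compound 3 (3.40 log units; beyond the scatter). Compound 2 gives > 10000 nM, which is a limit of the assay and not a number, so this step marks only a minimum size.

The compounds shown do not separate the contribution of the carbonyl from that of the two small rings. A cyclohexylcarbonyl group or a plain acetyl group on that nitrogen would help to tell them apart.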